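Guanidine series: dichlorophenyl variant, maximal response expected

The compounds below may be only part of what the source reports. "The series", "measured", "known", "first", "only" and "open" are said of these compounds alone.

Compound 1 `CN/C(=N\CCC(c1ccc(F)cc1)c1ccccn1)NCCCc1c[nH]cn1` and compound 2 `N=C(NCCCc1c[nH]cn1)NCCCC(c1ccccc1)c1ccccn1` share the imidazolylpropyl guanidine core and differ only in the aryl-pyridyl part. In an assay on cardiac atrium with histamine H2 receptor (Cavia porcellus) as the target (a lower number here means a smaller maximal response, a higher number a larger maximal response), compound 1 gives 1. Compound 2 gives 1 in this assay, level with compound 1 within the scatter, so both reach the full reference response. Compound 3 `N=C(NCCCc1c[nH]cn1)NCCCC(c1ccc(Cl)c(Cl)c1)c1ccccn1` is not yet measured. Its change from compound 2: 3,4-dichlorophenyl in place of phenyl on a saturated chain carbon bound to an aromatic carbon and a saturated chain carbon. Going by the values given here, no step between measured compounds is available to scale this change, so no movement beyond the scatter is expected in this assay. Compound 3 is estimated at 0.95, range 0.7 to 1. The expected step is a number 0.050 lower from compound 2 to compound 3 (within the scatter).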

Compound 3, intrinsic activity: the largest response reached, as a fraction of the reference agonist's: 1
Compound 3: middle estimate off by 0.050, on the low side; the range from low to high includes it.
By their numbers in this assay, from the lowest: compounds 1, 2 and 3 (each within the scatter of the next).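

On the saturated chain carbon bound to an aromatic carbon and a saturated chain carbon, 3,4-dichlorophenyl in place of phenyl gives no change at the digits printed from compound 2 to compound 3 (within the scatter) in this assay. Going by these compounds alone, this is the first single-place step, and it shows that this position accepts the two chlorine atoms with the maximal response unmoved. No available measurement bears on the reason for this.

Going by these compounds, whether an amine or a methoxy group on the phenyl ring would also leave the maximal response unmoved stays open. A maximal response also leaves open how compound 2 and compound 3 compare in potency.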